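Swapping a Methylphenyl for a Pyridyl: Cytotoxicity Outlook

The source may report more compounds than this note shows. Statements on the series, on what has been measured and on what is new or still open speak of the compounds shown alone.

Compound 1 `COc1cc(CC(O)c2ccc(-c3ccc(C)cc3)cc2)c([N+](=O)[O-])cc1OC` and compound 2 `COc1cc(CC(O)c2ccc(-c3ccccc3C#N)cc2)c([N+](=O)[O-])cc1OC` share one core and differ only in the aromatic group attached to it. In an ADME assay on HeLa Rh cells (Homo sapiens) for cytotoxicity, read by microscopy (on this read-out higher numbers stand for lower toxicity in this test and lower numbers for higher toxicity in this test), compound 1 gives 4700 nM, and compound 2 gives 9300 nM. Of these two numbers, compound 1 has the lower one, but the step of a 2.0-fold higher number from compound 1 to compound 2 (0.30 log units; within the scatter) lies within the scatter, so the two compounds cannot be told apart on toxicity here.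

Compound 3 `COc1cc(CC(O)c2ccc(-c3cccnc3)cc2)c([N+](=O)[O-])cc1OC` is the next case: relative to compound 1 the change is pyridin-3-yl in place of 4-methylphenyl on an aromatic carbon. Going by the values given here, the only measured step that bears on it is the one from compound 1 to compound 2, also an exchange of the aromatic group at this position, and it stayed within the scatter. A step of similar size, a 1.3-fold higher number from compound 1 to compound 3 (0.11 log units; within the scatter), is therefore expected, with no clear direction beyond the scatter. Compound 3 is estimated at 6000 nM, within 2500 nM to 15000 nM.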

Compound 3, half-maximal cytotoxic concentration: > 263000 nM
Compound 3 ended at the assay's limit; the forecaster's own chance of this, stated with the estimate: 5%; middle value at least 43-fold (1.64 log units) from the limit.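

In this assay compound 3 reads as a limit of the assay, not as a number: the limit of > 263000 nM in this assay, at which 1 of the 3 values shown sits. Going by these compounds alone, the only earlier exchange at this position stayed within the scatter, whereas pyridin-3-yl brings an at least 55-fold higher number from compound 1 to compound 3 (1.74 log units; beyond the scatter) and also an at least 28-fold higher number from compound 2 to compound 3 (1.45 log units; beyond the scatter), both beyond the scatter. The group on this aromatic carbon can therefore shift the reading strongly toward lower toxicity in this test, and the group that does so carries a ring nitrogen, counted as a hydrogen-bond acceptor, which 4-methylphenyl lacks.

A single pyridine among these compounds cannot show whether the ring nitrogen alone accounts for the shift. From the compounds shown here alone, it is also open how a phenyl ring bearing an amine or a carboxylic acid would read at this position.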